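The source may hold more compounds than are shown below. What is called first, only, known or untested is meant among the compounds shown, and "the series" means these compounds.

Working notes on the series. Compound 1 `C/C=C(\C)C(=O)Nc1ccn([C@H]2CC[C@H](O[C@H]3O[C@H](C)[C@@H](N(C)C)[C@H](O)[C@H]3O)[C@@H](C)O2)c(=O)n1` gives 6450 nM in a functional assay on HCT-116 cells (Homo sapiens) for cytotoxicity, read by sulforhodamine B assay, with a stated time of 24 h; a lower number here means a stronger inhibitor, a higher number a weaker inhibitor. Among the measured compounds shown here, compound 2 `CC(C)CC(=O)Nc1ccn([C@H]2CC[C@H](O[C@H]3O[C@H](C)[C@@H](N(C)C)[C@H](O)[C@H]3O)[C@@H](C)O2)c(=O)n1` gives 2140 nM in the same readout, and the step of a 3.0-fold lower number from compound 1 to compound 2 (0.48 log units; beyond the scatter) is the only measured change at the carbonyl carbon in this set. Compound 3 `CC(C)=CCC(=O)Nc1ccn([C@H]2CC[C@H](O)[C@@H](C)O2)c(=O)n1` lacks the sugar of the first two and reports only a limit, > 20000 nM, so compound 3 stands at the limit of > 20000 nM in this assay, at which 1 of the 3 values shown sits, and no number is known for it.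

Compound 4 `CC(C)C(=O)Nc1ccn([C@H]2CC[C@H](O)[C@@H](C)O2)c(=O)n1` keeps the core of compound 3 and differs only in the acyl group: isopropyl in place of 3-methylbut-2-en-1-yl on a carbonyl carbon. The measured step from compound 1 to compound 2, which likewise trades an unsaturated branched group for a saturated one on the carbonyl carbon, bears on this change, but it was modest and was read on a core carrying the sugar. The expected step for compound 4 is therefore small, a number no higher from compound 3 to compound 4 (the limit leaves the size open), and since compound 3 is known only as a limit, compound 4 is expected most likely to return a limit as well, estimated at 20000 nM with a range from 7000 nM to 60000 nM.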

Compound 4, half-maximal inhibitory concentration: > 20000 nM
Compound 4 gave a limit, no number; the forecaster's own chance of this, stated with the estimate: 65%; the middle value lies on the limit itself.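

In this assay, among the compounds shown here, compound 3 and compound 4 both give only a limit, so no step between them can be read: the limit of > 20000 nM in this assay, at which 2 of the 4 values shown sit. The compounds shown leave open whether exchanging the acyl group changes the readout at all on the core of compound 3.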